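Moving the Fluorine Around the Phenyl Ring

This account rests on a few compounds, and the source may have more. Where it says the series, first, only, none or still open, it means among the compounds named here.

Among the compounds with values here, compound 2 `CN1CCN(c2nc(N)nc(Cc3ccccc3F)n2)CC1` gives 88 nM in an assay on HEK293 cells for displacement of a labelled ligand from 5-hydroxytryptamine receptor 6 (Homo sapiens) (a lower number here means a stronger inhibitor, a higher number a weaker inhibitor), the higher of the two numbers measured so far; compound 1 `CN1CCN(c2nc(N)nc(Cc3cccc(Cl)c3)n2)CC1` gives 28 nM in this assay, and a 3.1-fold higher number from compound 1 to compound 2 (0.50 log units; beyond the scatter). Compound 3 `CN1CCN(c2nc(N)nc(Cc3ccc(F)cc3)n2)CC1` keeps the same atoms, joined differently: 4-fluorophenyl in place of 2-fluorophenyl on a saturated chain carbon bound to an aromatic carbon. Within the data shown here, the only measured step, from compound 1 to compound 2, changed both the halogen and where on the phenyl ring it sits, so it bears only loosely on this change and gives no firm direction. The step is therefore expected to be a 1.5-fold lower number from compound 2 to compound 3 (0.17 log units; within the scatter), possibly within the scatter. Compound 3 is estimated at 60 nM, with a range from 20 nM to 180 nM.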

Compound 3, inhibition constant: 100 nM
For compound 3 the middle estimate is 1.7-fold (0.22 log units) below the measured one; measured number inside the range.
By their numbers in this assay, from the lowest: compound 1; then compounds 2 and 3 (each within the scatter of the next).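

In this assay, moving the fluorine from 2-fluorophenyl to 4-fluorophenyl gives a 1.1-fold higher number from compound 2 to compound 3 (0.06 log units; within the scatter) and so separates nothing at this position. Against 3-chlorophenyl, 4-fluorophenyl gives a 3.6-fold higher number from compound 1 to compound 3 (0.55 log units; beyond the scatter) and lies on the same side as the step to compound 2, which leaves compound 1 apart from both fluorine compounds. No evidence at hand explains these numbers. From the compounds shown here alone, whether compound 1 owes its number to the chlorine or to where the chlorine sits remains open. So does what a methoxy group or an amine would do on this phenyl ring.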